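Swapping methyl for chloro on the triazole aryl ring

The source may hold more compounds than are shown below. What is called first, only, known or untested is meant among the compounds shown, and "the series" means these compounds.

The series shares one core and a hydroxamic acid tail, differing only in the aryl groups on the central ring. In a functional assay on MGC-803 cells (Homo sapiens) for antiproliferative activity, read by MTT assay, with a stated time of 72 h (on this read-out lower numbers stand for stronger inhibition and higher numbers for weaker inhibition), compound 1 `Cc1cccc(-c2nc(CNc3ccc(C(=O)NO)cc3)n(-c3ccccc3)n2)c1` gives 8710 nM, the lowest of the three numbers recorded, though its gaps to the others fall within the scatter. Compound 2 `O=C(NO)c1ccc(NCc2nc(-c3ccccc3)nn2-c2cccc(Cl)c2)cc1` gives 13700 nM, and compound 3 `O=C(NO)c1ccc(NCc2nc(-c3ccccc3)nn2-c2ccc(F)cc2)cc1` gives 10500 nM. For the measured compounds named here, the only step between measured compounds, a 1.3-fold lower number from compound 2 to compound 3 (0.12 log units; within the scatter), exchanges substituents on the aryl group attached to the aromatic nitrogen and does not leave the scatter.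

Compound 4 `O=C(NO)c1ccc(NCc2nc(-c3cccc(Cl)c3)nn2-c2ccccc2)cc1` differs from compound 1 by chloro in place of methyl on an aromatic carbon. Going by the values given here, this change sits on the other aryl group, the one attached to a ring carbon, so no measured step addresses it directly. Among the compounds with values here, the only available step, from compound 2 to compound 3, shows that a halogen swap on a peripheral aryl ring changed little. Compound 4 is therefore expected to show a step of a 1.0-fold higher number from compound 1 to compound 4 (0.01 log units; within the scatter), with no change beyond the scatter, and an estimated value of 9000 nM within 4500 nM to 18000 nM.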

Compound 4, half-maximal inhibitory concentration: 5760 nM
Beside the measured number, compound 4's estimate is 1.6-fold (0.19 log units) above it; measured number inside the range.
By their numbers in this assay, from the lowest: compounds 4, 1, 3 and 2 (each within the scatter of the next, the first and the last beyond it).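

In this assay, for the compounds shown here, the exchange of 3-methylphenyl for 3-chlorophenyl gives a 1.5-fold lower number from compound 1 to compound 4 (0.18 log units; within the scatter) and is the only measured step on the aryl group attached to a ring carbon of the shared core. Going by these compounds alone, at this place, on an aromatic carbon meta to a large group, the read-out therefore does not separate chloro from methyl, just as the one earlier step on the other aryl group stayed within the scatter. Nothing available here explains the result.

The compounds shown leave open whether this position responds at all to a group of a different kind, such as an amine, a carboxylic acid or a methoxy group. They also leave open whether chloro on this ring would give the same result with a substituent on the other aryl group.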